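Cytotoxicity notes on compounds 1 to 4

This account rests on a few compounds, and the source may have more. Where it says the series, first, only, none or still open, it means among the compounds named here.

Measured compounds:
compound 1, `O=c1n(Cc2cn3ccc(Cl)cc3n2)c2cnccc2n1C1CC1` — 22300 nM
compound 2, `CS(=O)(=O)CCNC(=O)c1c(Cn2c(=O)n(C3CC3)c3ccncc32)nc2cc(Cl)ccn12` — > 100000 nM, a limit
compound 3, `O=c1n(Cc2nc3cc(Cl)ccn3c2NC2CCCCC2)c2cnccc2n1C1CC1` — > 100000 nM, a limit

Among the measured compounds shown here, in an ADME assay on HEp-2 cells (Homo sapiens) for cytotoxicity, read by CCK-8 assay, with a stated time of 6 days (on this read-out higher numbers stand for lower toxicity in this test and lower numbers for higher toxicity in this test), compound 1 gives 22300 nM, and this is the only number in the set. For compound 2 the value > 100000 nM is a limit of the assay rather than a number. For compound 3 the value > 100000 nM is likewise a limit. For the measured compounds named here, compound 1 therefore stands as the single compound of the three with a read-out inside the measured window, and as the one with the higher toxicity in this test.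

Compound 4, `CS(=O)(=O)c1ccc(-c2c(Cn3c(=O)n(C4CC4)c4ccncc43)nc3cc(Cl)ccn23)cc1`, is not yet measured. It differs from compound 1 by 4-(methylsulfonyl)phenyl in place of hydrogen on an aromatic carbon. Two measured steps place a group on that same aromatic carbon and so bear on it: an at least 4.4-fold higher number from compound 1 to compound 2 (0.65 log units; beyond the scatter) and an at least 4.4-fold higher number from compound 1 to compound 3 (0.65 log units; beyond the scatter). Both run toward lower toxicity in this test. Between the two substituted compounds, a step that the two limits leave unreadable from compound 2 to compound 3. the limit of > 100000 nM in this assay, at which 2 of the 3 values shown sit, is where both substituted analogues sit, so the upper end of the window is the likely outcome for a third substituent here as well.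

For compound 4 a step in the same direction is expected, a 4.5-fold higher number from compound 1 to compound 4 (0.65 log units; beyond the scatter), with a good chance that only a limit is returned. Compound 4 is estimated at 100000 nM, with a range from 35000 nM to 300000 nM.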

Compound 4, half-maximal cytotoxic concentration: > 100000 nM
Compound 4: only a limit was reported (the forecaster's own chance of this, stated with the estimate: 60%); the middle value lies on the limit itself.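

In this assay, placing 4-(methylsulfonyl)phenyl on the aromatic carbon of the five-membered ring gives an at least 4.4-fold higher number from compound 1 to compound 4 (0.65 log units; beyond the scatter), a step that rests on a limit for compound 4. This adds an aromatic ring of carbon only to the (2-(methylsulfonyl)ethyl)carbamoyl of compound 2 and the cyclohexylamino of compound 3, so three different groups at this position now all run toward lower toxicity in this test, with no compound shown going against that direction. The steps among compound 2, compound 3 and compound 4 cannot be read, which leaves these three groups unranked, and the series now presses against a common ceiling: the limit of > 100000 nM in this assay, at which 3 of the 4 values shown sit.

Open, going by these compounds, is whether a much smaller group on this carbon, such as methyl, a plain amine or a carboxylic acid, would also reach the limit or would return a number that gives the change a real size. Also open, on these data alone, is how far compound 2, compound 3 and compound 4 differ from one another, since their read-outs give no order.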